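Swapping 4-fluorophenyl for 3,4-dichlorophenyl

This account rests on a few compounds, and the source may have more. Where it says the series, first, only, none or still open, it means among the compounds named here.

- Compound 1 `COc1ccc(/C=C2\CN(C)C/C(=C\c3ccccc3F)C2=O)cc1OC` gives 10500 nM
- Compound 2 `COc1cc(/C=C2\CN(C)C/C(=C\c3ccc(C#N)cc3)C2=O)cc(OC)c1OC` gives 18600 nM
- Compound 3 `CN1C/C(=C\c2ccc(F)cc2)C(=O)/C(=C/c2cccc([N+](=O)[O-])c2)C1` gives 17600 nM
- Compound 4 `CN1C/C(=C\c2cccc([N+](=O)[O-])c2)C(=O)/C(=C/c2ccc(Cl)c(Cl)c2)C1` has not been measured yet

In an ADME assay on L02 cells (Homo sapiens) for cytotoxicity, read by MTT assay, with a stated time of 24 h (on this read-out higher numbers stand for weaker inhibition and lower numbers for stronger inhibition), compound 3 (17600 nM) lies within the usual scatter of both compound 1 and compound 2, so the numbers give these compounds no real order. Moving on to compound 4, the change is 3,4-dichlorophenyl in place of 4-fluorophenyl on a double-bonded chain carbon bound to a double-bonded ring carbon and it places 3,4-dichlorophenyl in place of 4-fluorophenyl on a double-bonded chain carbon bound to a double-bonded ring carbon. Going by the values given here, no two measured compounds differ in one place only, so there is no direct guide to this swap. Compound 1 (10500 nM) and compound 2 (18600 nM) carry different groups, yet their values also lie within the scatter of each other. The estimated change (a 1.3-fold lower number from compound 3 to compound 4 (0.10 log units; within the scatter)) is therefore expected to stay within the usual scatter, with no real shift in either direction. For compound 4 the expected value is 14000 nM (estimated range 6500 nM to 30000 nM).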

Compound 4, half-maximal inhibitory concentration: 14800 nM
Beside the measured number, compound 4's estimate is 1.1-fold (0.02 log units) below it; low and high end bracket the measured number.
By their numbers in this assay, from the lowest: compounds 1, 4, 3 and 2 (each within the scatter of the next).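

Going by these compounds alone, replacing 4-fluorophenyl with 3,4-dichlorophenyl on a double-bonded chain carbon bound to a double-bonded ring carbon gives a 1.2-fold lower number from compound 3 to compound 4 (0.08 log units; within the scatter) in this assay and provides the first direct reading for this position. With the rest of the molecule held the same, exchanging these two halogen-bearing phenyl groups leaves no real shift in the number. Nothing measured here explains this result.

Going by these compounds, it remains open whether this position would stay equally unresponsive with an amine or a carboxylic acid on the phenyl ring, or with a longer chain in place of that ring. On these data alone, it is also open whether the same swap would read alike when the rest of the molecule differs.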